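Methyl extension on the chain across two cores

A few compounds are considered here, and "the series" means these few. Any claim that something is new, unique, unknown or untested is made for them only; others in the source may bear on it.

Compound 1 `CCCCCCCCCCn1cc(-c2nc3ccccc3cc2CCCC)nn1` and compound 2 `CCCCCCCCCCn1cc(-c2nc3ccccc3cc2CCCCC)nn1` share one core; compound 3 `CCCc1cc2ccccc2nc1-c1cn(-c2ccc(F)cc2)nn1` and the unmeasured compound 4 `CCCCc1cc2ccccc2nc1-c1cn(-c2ccc(F)cc2)nn1` share another. The difference between the two cores is not broken down here.

In a functional assay on COLO 205 cells (Homo sapiens) for cytotoxicity, read by MTT assay, with a stated time of 24 h (on this read-out higher numbers stand for weaker inhibition and lower numbers for stronger inhibition), compound 1 gives > 100 ug/mL, which is a limit of the assay. In this assay compound 2 gives > 100 ug/mL, also a limit. In this assay compound 3 gives > 100 ug/mL, again a limit. All three values sit at the limit of > 100 ug/mL in this assay, at which 3 of the 3 values shown sit.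

The change made within the first pair is methyl in place of hydrogen on a saturated chain carbon, four bonds along the chain from an aromatic carbon. Its step, a step that the two limits leave unreadable from compound 1 to compound 2, cannot be read because both values rest at the limit of > 100 ug/mL in this assay, at which 3 of the 3 values shown sit.

Compound 4 carries the same kind of change, (methyl in place of hydrogen on a saturated chain carbon, three bonds along the chain from an aromatic carbon), the place differing in that the carbon lies three bonds along the chain from an aromatic carbon rather than four. The step that the limit leaves unreadable from compound 3 to compound 4 is expected to be small in this assay, resting on the unreadable step that the two limits leave unreadable from compound 1 to compound 2 in the first pair, where adding the methyl did not bring either compound inside the measurable range.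

Compound 4 is estimated at 150 ug/mL in this assay, between 60 ug/mL and 400 ug/mL, most likely reported only as a limit.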

Compound 4, half-maximal inhibitory concentration: > 100 ug/mL
Compound 4: a limit, no number; the forecaster's own chance of this, stated with the estimate: 80%; the middle value is on the limit's open side.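

In this assay compound 4 gives > 100 ug/mL, a limit of the assay and not a number, so neither the step from compound 3 to compound 4 nor the step from compound 1 to compound 2 can be read: the limit of > 100 ug/mL in this assay, at which 4 of the 4 values shown sit.

The compounds shown leave open whether any chain on either core gives a value inside the measurable range of this assay.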